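Methoxy in Place of Trifluoromethyl on the Benzyl Thioether

The source may report more compounds than this note shows. Statements on the series, on what has been measured and on what is new or still open speak of the compounds shown alone.

Measured compounds:
compound 1 `C#CCNC1CCc2c(SCc3cccc(Cl)c3)cccc21`, 23300 nM
compound 2 `C#CCNC1CCc2c(SCc3cccc(C(F)(F)F)c3)cccc21`, 4.7 nM

In an assay on isolated protein for inhibition of Amine oxidase [flavin-containing] B (Homo sapiens) (on this read-out higher numbers stand for weaker inhibition and lower numbers for stronger inhibition), compound 2 gives 4.7 nM, the lowest of the two numbers; its nearest neighbour is compound 1 at 23300 nM. Among the compounds with values here, the one measured step, a 5000-fold lower number from compound 1 to compound 2 (3.70 log units; beyond the scatter), shows how strongly this aromatic position responds to a change of substituent. Compound 3 `C#CCNC1CCc2c(SCc3cccc(OC)c3)cccc21` carries methoxy in place of trifluoromethyl on an aromatic carbon. Within the data shown here, no measured step bears on a methoxy here, so the direction is uncertain; compound 3 is expected to sit between the two measured numbers, with an estimated 110-fold higher number from compound 2 to compound 3 (2.03 log units; beyond the scatter). The estimate for compound 3 is 500 nM, within 20 nM to 15000 nM.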

Compound 3, half-maximal inhibitory concentration: 3190 nM
The estimate for compound 3 lay 6.4-fold (0.80 log units) below the measured number, within the range that was stated.
By their numbers in this assay, from the lowest: compound 2; then compound 3; then compound 1.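

In this assay the change to methoxy gives a 680-fold higher number from compound 2 to compound 3 (2.83 log units; beyond the scatter), and measured against chloro it gives a 7.3-fold lower number from compound 1 to compound 3 (0.86 log units; beyond the scatter). All three groups at this aromatic carbon are therefore separated beyond the scatter, and methoxy stands much nearer to chloro than to trifluoromethyl, which alone reaches the low end of the range. No available evidence accounts for these differences. Still open, on these data alone, is whether a nitrile or a bromo group here would fall near trifluoromethyl or stay with chloro and methoxy.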